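Branching the Amide Chain: From Propyl to Isopropyl

The source may hold more compounds than are shown below. What is called first, only, known or untested is meant among the compounds shown, and "the series" means these compounds.

In a functional assay on MCF7 cells (Homo sapiens) for antiproliferative activity, read by sulforhodamine B assay, with a stated time of 48 h (on this read-out lower numbers stand for stronger inhibition and higher numbers for weaker inhibition), compound 1 `CC(=O)Nc1cccc(S(=O)(=O)Oc2ccccc2C(C)C)c1` gives 21000 nM, compound 2 `CCCC(=O)Nc1cccc(S(=O)(=O)Oc2ccccc2C(C)C)c1` gives 9400 nM, and compound 3 `CCCCCC(=O)Nc1cccc(S(=O)(=O)Oc2ccccc2C(C)C)c1` gives 12000 nM. Compound 2 holds the lowest number of the three, though compound 3 sits within the scatter of it. Compound 4 `CC(C)C(=O)Nc1cccc(S(=O)(=O)Oc2ccccc2C(C)C)c1` differs from compound 2 by isopropyl in place of propyl on a carbonyl carbon. The measured steps change only the length of this chain: a 2.2-fold lower number from compound 1 to compound 2 (0.35 log units; beyond the scatter), a 1.8-fold lower number from compound 1 to compound 3 (0.24 log units; within the scatter) and a 1.3-fold higher number from compound 2 to compound 3 (0.11 log units; within the scatter). Lengthening the chain moved the number modestly at most, and no measured step tests branching, so the step of a 1.0-fold higher number from compound 2 to compound 4 (0.00 log units; within the scatter) is expected to stay within the scatter. Compound 4 is therefore estimated at 9500 nM, with a likely range from 4500 nM to 20000 nM.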

Compound 4, half-maximal inhibitory concentration: 13000 nM
For compound 4 the middle estimate is 1.4-fold (0.14 log units) below the measured one; the measured number falls inside the stated range.
By their numbers in this assay, from the lowest: compounds 2, 3, 4 and 1 (each within the scatter of the next, the first and the last beyond it).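

Compound 4 adds branching on the carbonyl carbon to a set that otherwise varied only chain length. In this assay it stays within the scatter of every other compound shown (a 1.4-fold higher number from compound 2 to compound 4 (0.14 log units; within the scatter); a 1.1-fold higher number from compound 3 to compound 4 (0.03 log units; within the scatter); a 1.6-fold lower number from compound 1 to compound 4 (0.21 log units; within the scatter)), so joining the same three carbons as isopropyl rather than propyl gives no readable difference here, and no measured evidence on offer bears on this result. Still open, on these data alone, is how a cyclopropyl or phenyl ring, or an amine on the chain, would read at this position.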